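Allyloxy in place of aminobutoxy on a shared isoflavone-type core

This account rests on a few compounds, and the source may have more. Where it says the series, first, only, none or still open, it means among the compounds named here.

Three compounds share one core. In an assay (Cricetulus griseus) for inhibition of aldehyde dehydrogenase, mitochondrial (Homo sapiens) (a higher number here means a weaker inhibitor, a lower number a stronger inhibitor), compound 2 `CCOc1ccc2c(=O)c(-c3ccc(O)cc3)coc2c1` gives 80 nM, compound 1 `CCOC(=O)COc1ccc2c(=O)c(-c3ccc(O)cc3)coc2c1` gives 130 nM, and compound 3 `NCCCCOc1ccc2c(=O)c(-c3ccc(O)cc3)coc2c1` gives 250 nM, the highest of the three numbers. Compound 4 `C=CCOc1ccc2c(=O)c(-c3ccc(O)cc3)coc2c1` differs from compound 3 by vinyl in place of 3-aminopropyl on a saturated chain carbon bound to an oxygen on an aromatic ring. The step from an ethoxy to an aminobutoxy chain is the one that bears on this change: a 3.1-fold higher number from compound 2 to compound 3 (0.49 log units; beyond the scatter), while a 1.9-fold higher number from compound 1 to compound 3 (0.28 log units; within the scatter) and a 1.6-fold lower number from compound 1 to compound 2 (0.21 log units; within the scatter). Removing the aminopropyl part again is therefore expected to move this assay back down, by roughly a 2.5-fold lower number from compound 3 to compound 4 (0.40 log units; beyond the scatter). Compound 4 is estimated at 100 nM, within a range of 50 nM to 200 nM.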

Compound 4, half-maximal inhibitory concentration: 180 nM
Beside the measured number, compound 4's estimate is 1.8-fold (0.26 log units) below it; the measured number falls inside the stated range.
By their numbers in this assay, from the lowest: compounds 2, 1, 4 and 3 (each within the scatter of the next, the first and the last beyond it).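

In this assay, allyloxy in place of aminobutoxy leaves the two compounds within the scatter (a 1.4-fold lower number from compound 3 to compound 4 (0.14 log units; within the scatter)), so losing the amine here does not restore the number of compound 2. Vinyl in place of methyl is the one new step beyond the scatter (a 2.3-fold higher number from compound 2 to compound 4 (0.35 log units; beyond the scatter)), whereas vinyl in place of ethoxycarbonyl is not (a 1.4-fold higher number from compound 1 to compound 4 (0.14 log units; within the scatter)). No measured evidence accounts for these steps. On these data alone, it remains open whether a saturated propoxy chain would read like compound 2 or like compound 4, and how a carboxylic acid or a longer alkyl chain would read at this place.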